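The source may hold more compounds than are shown below. What is called first, only, known or untested is meant among the compounds shown, and "the series" means these compounds.

Compound 3 `COc1cccc(CNCCCNc2ccnc3cc(Cc4ccc(C#N)cc4)ccc23)c1O` gives 23 10^-6 cm/s in an ADME assay for permeability, using PAMPA, with a stated time of 30 min, at pH 7.4 (on this read-out higher numbers stand for higher permeability and lower numbers for lower permeability), level with compound 1 `COc1ccc(F)cc1CNCCCNc1ccnc2cc(CC(C)C)ccc12` at 23 10^-6 cm/s and compound 2 `COc1ccc(F)cc1CNCCCNc1ccnc2cc(Cc3ccc(C#N)cc3)ccc12` at 23 10^-6 cm/s. Compound 4 `COc1cccc(CNCCCNc2ccnc3cc(-c4ccc(C(C)(C)C)cc4)ccc23)c1O` differs from compound 3 by 4-(tert-butyl)phenyl in place of 4-cyanobenzyl on an aromatic carbon. The measured step most alike, no change at the digits printed from compound 1 to compound 2 (within the scatter), exchanged a group on a saturated chain carbon bound to an aromatic carbon; the other step, no change at the digits printed from compound 2 to compound 3 (within the scatter), altered the group on a saturated chain carbon bound to an amine nitrogen. Both were flat, so the expected step of no change at the digits printed from compound 3 to compound 4 (within the scatter) is none beyond the scatter. Compound 4 is therefore estimated at 23 10^-6 cm/s, with a range from 12 10^-6 cm/s to 40 10^-6 cm/s.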

Compound 4, apparent permeability: 237 10^-6 cm/s
Estimate against measurement, compound 4: 10-fold (1.01 log units) below; the measured number lies above the stated range.
By their numbers in this assay, from the lowest: compounds 1, 2 and 3 (each within the scatter of the next); then compound 4.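

In this assay, within the data shown here, 4-(tert-butyl)phenyl in place of 4-cyanobenzyl on this aromatic carbon gives a 10-fold higher number from compound 3 to compound 4 (1.01 log units; beyond the scatter), the first step here beyond the scatter. The group held at this place can therefore move the read-out, although the earlier exchange on the chain carbon bound here left it flat. The data give no measured property that bears on the reason for this rise. From the compounds shown here alone, the nitrile and the saturated chain carbon leave together, so their shares stay open. A 4-(tert-butyl)benzyl group or an unsubstituted phenyl would separate them.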